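Replacing the tert-butylcyclohexyl group on the glucagon receptor antagonist core

A few compounds are considered here, and "the series" means these few. Any claim that something is new, unique, unknown or untested is made for them only; others in the source may bear on it.

Compound 1 `CC(C)(C)[C@H]1CC[C@H](c2cc(-c3ccc(OC(F)(F)F)cc3)nn2Cc2ccc(C(=O)NCCC(=O)O)cc2)CC1`: "not determined" (no result reported)
Compound 2 `CC(C)(C)[C@H]1CC[C@H](c2cc(-c3ccc(OC(F)(F)F)cc3)nn2Cc2ccc(C(=O)Nc3nn[nH]n3)cc2)CC1`: 170 nM

In a functional assay on CHO cells for antagonist activity at Glucagon receptor (Homo sapiens), read by cAMP accumulation (on this read-out higher numbers stand for weaker inhibition and lower numbers for stronger inhibition), compound 2 gives 170 nM, while compound 1 has no single number and so stands nowhere on the scale. Compound 3 `O=C(O)CCNC(=O)c1ccc(Cn2nc(-c3ccc(OC(F)(F)F)cc3)cc2-c2ccc(OC(F)(F)F)cc2)cc1` differs from compound 1 by 4-(trifluoromethoxy)phenyl in place of 4-(tert-butyl)cyclohexyl on an aromatic carbon. Among the compounds with values here, with no measured step to draw on, the size of this change is open; a move toward weaker inhibition in this assay, beyond the scatter, is expected. Compound 3 is estimated at 1200 nM, between 250 nM and 6000 nM.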

Compound 3, half-maximal inhibitory concentration: 370 nM
For compound 3 the middle estimate is 3.2-fold (0.51 log units) above the measured one; the measured number falls inside the stated range.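

Within the data shown here, compound 1 has no single number in this assay, so no step from it to compound 3 can be read. The compounds shown leave open what 4-(trifluoromethoxy)phenyl in place of 4-(tert-butyl)cyclohexyl does to inhibition. Nothing further shown here bears on this result.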